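The source may hold more compounds than are shown below. What is called first, only, known or untested is meant among the compounds shown, and "the series" means these compounds.

Values so far in a functional assay on NCI-H522 cells (Homo sapiens) for cytotoxicity, read by sulforhodamine B assay, with a stated time of 48 h (a lower number here means a stronger inhibitor of growth, a higher number a weaker inhibitor of growth), are these
- compound 1 `COc1cc(C(=O)c2ccc(OC)c(O)c2OC)cc(OC)c1O` gives 290 nM in this series
- compound 2 `COc1cc(C(=O)c2ccc3c(c2)oc(=O)n3S(C)(=O)=O)cc(OC)c1OC` gives 2340 nM in this series

Compound 1 holds the lower of the two numbers, and compound 2 lies above it by a gap beyond the scatter. Among the compounds with values here, the two compounds differ in more than one place, so no single change has yet been measured, and compound 2 gives no size for the step considered here.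

Compound 3 `COc1ccc(C(=O)c2cc(OC)c(OC)c(OC)c2)c(OC)c1O` has not yet been measured. It differs from compound 1 in one place (methyl in place of hydrogen on an oxygen on an aromatic ring), with methyl in place of hydrogen on an oxygen on an aromatic ring, that is, hydroxy to methoxy. The starting point is compound 1 at 290 nM on the same core. In this assay a step to a lower number, beyond the scatter, is expected, though this is a judgement and not a measured trend. The estimated change is a 5.8-fold lower number from compound 1 to compound 3 (0.76 log units; beyond the scatter) and it carries wide uncertainty. For compound 3 the expected value is 50 nM (estimated range 10 nM to 250 nM).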

Compound 3, concentration for 50% growth inhibition: < 10 nM
Compound 3 ended at the assay's limit; the forecaster's own chance of this, stated with the estimate: 3%; middle value at least 5.0-fold (0.69 log units) from the limit.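

Hydroxy to methoxy on this oxygen is the first single change measured in the series, and it gives an at least 29-fold lower number from compound 1 to compound 3 (1.46 log units; beyond the scatter) on the shared core in this assay. At this place on the aromatic ring, a free hydroxy is therefore not needed for strong growth inhibition in this pair, and methyl in place of hydrogen goes with the much lower number, while compound 3 keeps the other hydroxy of compound 1. In this assay compound 3 gives < 10 nM and this value is a limit of the assay, not a number: the limit of < 10 nM in this assay, at which 1 of the 3 values shown sits.

Open, from the compounds shown here alone, are whether an ethyl on this oxygen, or an amine in place of the oxygen, would keep a number this low, and what the other hydroxy contributes to the value of compound 3. Going by these compounds, the true size of the step also stays open, and compound 2 differs from both of the other compounds in more than one place, so it adds no reading at this position.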